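Removing the Fluoro Group from Compound 2

The source may hold more compounds than are shown below. What is called first, only, known or untested is meant among the compounds shown, and "the series" means these compounds.

Of the compounds shown here, two that share one core have been measured in a functional assay on A375P cells (Homo sapiens) for cytotoxicity, read by MTT assay, with a stated time of 2 days; a lower number here means a stronger inhibitor, a higher number a weaker inhibitor. Compound 1 `CCCCCNc1nc(NCc2ccco2)c2cc(F)ccc2n1` carries a pentyl chain on one of its amine nitrogens, and in this assay compound 1 gives 7340 nM. Compound 2 `Cc1cccc(N2CCN(CCCCNc3nc(NCc4ccco4)c4cc(F)ccc4n3)CC2)c1C` replaces that chain with a longer, bulkier substituent, and in this assay compound 2 gives 3280 nM. Compound 2 therefore stands at the lowest of the two numbers, with compound 1 at a higher number by a margin beyond the usual scatter.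

Compound 3 `Cc1cccc(N2CCN(CCCCNc3nc(NCc4ccco4)c4ccccc4n3)CC2)c1C` differs from compound 2 in a single place: hydrogen in place of fluoro on an aromatic carbon, so hydrogen takes the place of fluoro on an aromatic carbon of the fused ring system. For the measured compounds named here, no pair of measured compounds shows this change, so there is nothing to gauge it against. The step of a 1.2-fold higher number from compound 2 to compound 3 (0.09 log units; within the scatter) is therefore expected to be small, with no clear direction beyond the scatter. Compound 3 is expected to give about 4000 nM in this assay, within a range from 1500 nM to 11000 nM.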

Compound 3, half-maximal inhibitory concentration: 3900 nM
For compound 3 the middle estimate is 1.0-fold (0.01 log units) above the measured one, and the stated range covers the measured number.
By their numbers in this assay, from the lowest: compounds 2, 3 and 1 (each within the scatter of the next, the first and the last beyond it).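

In this assay, putting hydrogen in place of fluoro on this aromatic carbon gives a 1.2-fold higher number from compound 2 to compound 3 (0.08 log units; within the scatter), the first step among these compounds that isolates this position. In this single pair, which carries the longer, bulkier substituent of compound 2, the fluoro group on this carbon, meta to a fused ring and para to a fused ring of the shared core, can be exchanged for hydrogen without a change beyond the scatter of the assay. No other evidence bears on this result, and the pair offers no explanation for it.

The compounds shown leave open whether the exchange of fluoro for hydrogen would read the same way with the pentyl chain of compound 1 in place of that larger substituent, as this one pair is the only view of the position. They also leave open how this aromatic carbon would respond to a group other than fluoro or hydrogen, such as chloro, methoxy, a nitrile or an amine.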